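The compounds below may be only part of what the source reports. "The series", "measured", "known", "first", "only" and "open" are said of these compounds alone.

Compound 1 `O=C(CCCCC1CCSS1)Nc1ccc(OC(F)(F)F)cc1`: 38.2%
Compound 2 `O=C(CCCCC(S)CCS)Nc1ccc(Cl)cc1`: "not determined" (no result reported)
Compound 3 `O=C(CCCCC(S)CCS)Nc1ccc(F)cc1`: "not determined" (no result reported)

All three compounds belong to one small set examined in a functional assay on PC-3 cells (Homo sapiens) for inhibition, read by MTT assay, with a stated time of 24 h, tested at 10 ug/mL; on this read-out higher numbers stand for more inhibition of growth at the one concentration tested and lower numbers for less inhibition of growth. Only compound 1 has a number there. Compound 3 stands without one, and compound 2 is in the same position, so neither can be ranked against compound 1.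

The next compound to be tested is compound 4 `O=C(CCCCC(S)CCS)Nc1ccc(OC(F)(F)F)cc1`. The structural change is trifluoromethoxy in place of fluoro on an aromatic carbon. For the measured compounds named here, no measured pair in this set shows what such a swap does, and the missing number for compound 3 means that no step can be calculated from it. No size or direction can therefore be expected for this step in this assay. Going by the values given here, the one available guide is compound 1 at 38.2%, which carries the same trifluoromethoxy group but differs from compound 4 elsewhere in its structure. For compound 4, the estimated value is 40%, with an expected range from 20% to 65%.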

Compound 4, percent growth inhibition at one concentration: 42.5%
Compound 4: middle estimate off by 2.5 percentage points, on the low side; the measured number falls inside the stated range.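

In this assay, exchanging the five-membered non-aromatic ring of compound 1 for the open sulfur-bearing chain of compound 4 gives a number 4.3 percentage points higher from compound 1 to compound 4 (within the scatter). With trifluoromethoxy on the aromatic ring, this assay therefore does not separate the closed form from the open form at the one concentration tested. The swap of fluoro for trifluoromethoxy itself cannot be read, as compound 3 has no number, and nothing available explains the result of the ring opening.

The compounds shown leave open whether the closed and open forms would also stay level with fluoro or chloro on the aromatic ring, since compound 2 also lacks a number. They also leave open what a nitrile or an amine would do on that aromatic carbon, or what a longer chain would do between the carbonyl and the sulfur-bearing end.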